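The source may report more compounds than this note shows. Statements on the series, on what has been measured and on what is new or still open speak of the compounds shown alone.

Measured compounds in a functional assay on HL-60 cells (Homo sapiens) for cytotoxicity, read by WST assay, with a stated time of 48 h; on this read-out higher numbers stand for weaker inhibition and lower numbers for stronger inhibition:

- Compound 1 `COc1cc(C(c2ccc(O)c(OC)c2)[C@@H](C)[C@H](C)CO)ccc1O` — reported only as a limit, > 100000 nM
- Compound 2 `COc1cc(C(c2ccc(O)c(OC)c2)[C@H](C)[C@@H](C)CF)ccc1O` — 45000 nM
- Compound 3 `COc1cc(C(c2ccc(O)c(OC)c2)[C@@H](CF)C(C)C)ccc1O` — 39000 nM

Compound 1 sits at a limit of this assay, (the limit of > 100000 nM in this assay, at which 1 of the 3 values shown sits). Among the two numbers, compound 3 gives the lowest, but compound 2 is within the scatter of it, so the two cannot be ranked. The step of a 1.2-fold lower number from compound 2 to compound 3 (0.06 log units; within the scatter) is small and within the scatter.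

Compound 4 `CC[C@H](C(C)C)C(c1ccc(O)c(OC)c1)c1ccc(O)c(OC)c1` has not yet been measured. It differs from compound 3 in one place: 1-isopropylpropyl in place of 1-(fluoromethyl)-2-methylpropyl on a saturated chain carbon bound to two aromatic carbons. Among the measured compounds shown here, the steps that bear on this change are an at least 2.5-fold lower number from compound 1 to compound 3 (0.40 log units; beyond the scatter) and an at least 2.2-fold lower number from compound 1 to compound 2 (0.34 log units; beyond the scatter), both at least modest and beyond the scatter, though each starts from a limit and so gives only a lower bound on its size. For the measured compounds named here, no measured step exchanges a fluoromethyl group for a carbon group, so the size of the next step is uncertain. Compound 4 is expected to show a 1.3-fold lower number from compound 3 to compound 4 (0.11 log units; within the scatter), a small change that may fall within the scatter. The estimate for compound 4 in this assay is 30000 nM, with a range from 12000 nM to 75000 nM.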

Compound 4, half-maximal inhibitory concentration: 16000 nM
For compound 4 the middle estimate is 1.9-fold (0.27 log units) above the measured one; low and high end bracket the measured number.
By their numbers in this assay, from the lowest: compound 4; then compounds 3 and 2 (each within the scatter of the next). At a limit, above all of these: compound 1.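

In this assay, the all-carbon 1-isopropylpropyl on a saturated chain carbon bound to two aromatic carbons separates from both fluoromethyl chains, which could not be told apart from each other: the data give a 2.4-fold lower number from compound 3 to compound 4 (0.39 log units; beyond the scatter) and a 2.8-fold lower number from compound 2 to compound 4 (0.45 log units; beyond the scatter), so a fluorine in this chain is not required for the lower number. Compound 4 therefore has the lowest number of the compounds shown, and against the hydroxymethyl chain the data give an at least 6.2-fold lower number from compound 1 to compound 4 (0.79 log units; beyond the scatter) as a lower bound only. That step starts from compound 1, whose value is a limit: the limit of > 100000 nM in this assay, at which 1 of the 4 values shown sits.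

The compounds shown leave open how a longer chain or an amine at this place would read in this assay. They also leave open what the opposite configuration of the defined stereocentre in 1-isopropylpropyl would give.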